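A few compounds are considered here, and "the series" means these few. Any claim that something is new, unique, unknown or untested is made for them only; others in the source may bear on it.

Two analogues sharing one core have been measured in an assay on isolated protein for inhibition of Polyunsaturated fatty acid 5-lipoxygenase (Homo sapiens), read by HPLC, with stated times of 15 min and 10 min; a higher number here means a weaker inhibitor, a lower number a stronger inhibitor. Compound 1 `COc1ccccc1Nc1nc(-c2ccc(Cl)cc2)cs1` gives 2700 nM, and compound 2 `Oc1cccc(Nc2nc(-c3ccc(Cl)cc3)cs2)c1` gives 1200 nM, the lower of the two numbers, with the number for compound 1 lying beyond the usual scatter above it. Compound 3 `Clc1ccc(-c2csc(Nc3ccccc3)n2)cc1` has not yet been measured; it differs from compound 2 by hydrogen in place of hydroxy on an aromatic carbon. Among the compounds with values here, no measured pair shows this change, so the expectation rests on compound 2 alone. Compound 3 is expected to give a somewhat higher number than compound 2, a step of a 2.1-fold higher number from compound 2 to compound 3 (0.32 log units; beyond the scatter). The estimate for compound 3 is 2500 nM, in the range 900 nM to 7000 nM.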

Compound 3, half-maximal inhibitory concentration: 700 nM
Beside the measured number, compound 3's estimate is 3.6-fold (0.55 log units) above it; measured number below the stated range.
By their numbers in this assay, from the lowest: compounds 3 and 2 (each within the scatter of the next); then compound 1.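

Hydrogen in place of hydroxy, on an aromatic carbon meta to a large group, gives a 1.7-fold lower number from compound 2 to compound 3 (0.23 log units; within the scatter), so the hydroxy at this position is not required for inhibition at this level. Hydrogen in place of methoxy gives a 3.9-fold lower number from compound 1 to compound 3 (0.59 log units; beyond the scatter), and this is the only step here that lies clearly beyond the usual variation. No supporting evidence bears on either step. Going by these compounds, whether an amine or a carboxylic acid on the same aromatic carbon would leave the number close to that of compound 3 remains open, as does the effect of a fluorine there.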